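The source may report more compounds than this note shows. Statements on the series, on what has been measured and on what is new or still open speak of the compounds shown alone.

Measured so far:
- compound 1, `COc1ccc(CN2C(=O)/C(=C\c3cc(OC)c(OC)c(OC)c3)c3ccccc32)cc1`: 1800 nM
- compound 2, `COc1cc(/C=C2\C(=O)N(C)c3ccc(Cl)cc32)cc(OC)c1OC`: 4000 nM

Both compounds share one core and carry a trimethoxyphenyl group on it. Compound 1 has the lower of the two numbers in a functional assay on cells (Cancer cell lines, Homo sapiens) for cytotoxicity, with a stated time of 48 h; a lower number here means a stronger inhibitor of growth, a higher number a weaker inhibitor of growth; the number for compound 2 is higher than that for compound 1 by a margin that lies beyond the usual scatter of repeated measurements. Compound 2 differs from compound 1 in more than one place, so the two values alone cannot say which of those changes matters.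

Compound 3, `COc1cc(/C=C2\C(=O)N(Cc3ccc(Cl)cc3)c3ccccc32)cc(OC)c1OC`, is not yet measured in this assay. It differs from compound 1 in one place: chloro in place of methoxy on an aromatic carbon. For the measured compounds named here, no measured pair shows this change by itself, so its effect must be guessed. A single small swap at the far end of a side chain, away from the core, is expected to move the number little, in either direction, and most likely by no more than the scatter. The step from compound 1 to compound 3 in this assay is estimated at a 1.2-fold higher number from compound 1 to compound 3 (0.09 log units; within the scatter). For compound 3 the expected value is 2200 nM, with a plausible range from 800 nM to 6000 nM.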

Compound 3, concentration for 50% growth inhibition: 2200 nM
For compound 3 middle estimate and measured number coincide at the digits printed, within the range that was stated.
By their numbers in this assay, from the lowest: compounds 1, 3 and 2 (each within the scatter of the next, the first and the last beyond it).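

For the compounds shown here, compounds 1 and 3 form the first pair that differs in only one place, so the effect of this swap can now be read directly in this assay: the step is a 1.2-fold higher number from compound 1 to compound 3 (0.09 log units; within the scatter). At this position, on an aromatic carbon para to a large group, going from 4-methoxybenzyl to 4-chlorobenzyl therefore gives two numbers that cannot be told apart, even though a hydrogen-bond acceptor leaves with the methoxy and chloro brings none, so this one swap gives no sign that the acceptor matters for growth inhibition in these cells. No measurement here explains why the swap has so little effect.

Going by these compounds alone, one pair covers only two groups at one position, so it remains open whether a very different group there, such as an amine, a carboxylic acid or a plain hydrogen, would also leave the number within the scatter. As far as these compounds go, it is also open whether the swap would behave in the same way on a compound that differs elsewhere on the shared core, or with a longer chain linking this aromatic ring to the core.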